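Growing out from chloro on the core of compound 1

A few compounds are considered here, and "the series" means these few. Any claim that something is new, unique, unknown or untested is made for them only; others in the source may bear on it.

The series rests on a shared core, seen in compound 1 `NC(=O)c1ccc(-c2cncc(Cl)c2)cc1`, compound 2 `NCCOc1cc(-c2cccnc2)ccc1C(N)=O` and compound 3 `CNC(=O)c1ccc(-c2cccnc2)cc1`. In an assay on cells for inhibition of MAP kinase-interacting serine/threonine-protein kinase 1 (Homo sapiens), read by mobility shift assay, with stated times of 10 min and 60 min, in the presence of a further agent that is not named here (a lower number here means a stronger inhibitor, a higher number a weaker inhibitor), compound 1 gives 14200 nM. Compound 2 gives 820 nM in this assay, and compound 3 gives 292000 nM. Compound 1 therefore stands second highest of the three numbers, beyond the scatter away from both neighbours: compound 2 sits well below it, compound 3 well above it.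

The next compound, compound 4 `Cn1cc(-c2cncc(-c3ccc(C(N)=O)cc3)c2)cn1`, is reached from compound 1 by a single change: 1-methyl-1H-pyrazol-4-yl in place of chloro on an aromatic carbon. Going by the values given here, no measured pair shows this change directly, so its effect cannot be read from the numbers at hand. The values of compound 2 and compound 3 show that changes away from the primary amide and around the core shift the number widely in either direction. Compound 4 is expected to give a moderate step downward, a 2.8-fold lower number from compound 1 to compound 4 (0.45 log units; beyond the scatter), beyond the scatter but not large. The estimate for compound 4 in this assay is 5000 nM, with a range from 1000 nM to 25000 nM.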

Compound 4, half-maximal inhibitory concentration: 800 nM
Estimate against measurement, compound 4: 6.3-fold (0.80 log units) above, outside the stated range (below it).
By their numbers in this assay, from the lowest: compounds 4 and 2 (each within the scatter of the next); then compound 1; then compound 3.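

In this assay, 1-methyl-1H-pyrazol-4-yl in place of chloro gives an 18-fold lower number from compound 1 to compound 4 (1.25 log units; beyond the scatter), so this change on an aromatic carbon two atoms from the ring nitrogen is a large one. Going by these compounds alone, it is the first direct reading at this position, and it shows that six heavy atoms with a five-membered aromatic ring can enter where a single chlorine stood while the number falls rather than rises. Nothing at hand accounts for the size of this step.

Within the data shown here, the single pair cannot separate the contribution of the ring from that of its two nitrogens or its methyl. A plain phenyl ring or a pyrazole without the methyl at the same position would be needed to tell these apart, and an amine or a longer chain there would show how far the position can be grown.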